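This account rests on a few compounds, and the source may have more. Where it says the series, first, only, none or still open, it means among the compounds named here.

Compound 1 `CCCNC(=O)N(O)c1cc([C@H]2CC[C@H](c3cc(OC)c(OC)c(OC)c3)O2)cc(OCCC)c1OCCC` gives 91 nM in an assay for binding affinity to platelet-activating factor receptor (Homo sapiens); on this read-out lower numbers stand for stronger inhibition and higher numbers for weaker inhibition.
Compound 2 `CCCOc1c(NC(=O)N(O)C(C)(C)C)cc(C2CCC(c3cc(OC)c(OC)c(OC)c3)O2)cc1OC` gives 26 nM; 456 nM (2 entries) in this assay.
Compound 3 `CCCOc1c(NC(=O)N(O)C2CCCCC2)cc(C2CCC(c3cc(OC)c(OC)c(OC)c3)O2)cc1OC` gives 1000 nM; 278 nM (2 entries) in this assay.

Within the data shown here, compound 1 stands with the only single number of its own; two further entries for it gave no single number. The spread within the repeated entries of compound 2 (the several entries of compound 2 in this assay, 26 nM; 456 nM (2 entries)) and of compound 3 (the several entries of compound 3 in this assay, 1000 nM; 278 nM (2 entries)) shows how widely this assay can scatter, so no ordering among the three is claimed.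

Compound 4 `CCCOc1cc([C@H]2CC[C@H](c3cc(OC)c(OC)c(OC)c3)O2)cc(N(CC)C(=O)N(C)O)c1OCCC` is the unmeasured partner of compound 1: ethyl(hydroxy(methyl)carbamoyl)amino in place of hydroxy(propylcarbamoyl)amino on an aromatic carbon. Among the measured compounds shown here, no comparison between measured compounds covers such a rearrangement, so no step beyond the scatter is expected in either direction, only a wide range. Compound 4 is estimated at 150 nM, between 30 nM and 800 nM, which means an expected step of a 1.6-fold higher number from compound 1 to compound 4 (0.22 log units; within the scatter).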

Compound 4, half-maximal inhibitory concentration: 68 nM
Estimate against measurement, compound 4: 2.2-fold (0.34 log units) above; low and high end bracket the measured number.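

Putting ethyl(hydroxy(methyl)carbamoyl)amino in place of hydroxy(propylcarbamoyl)amino on this aromatic carbon, ortho to a propoxy group, gives a 1.3-fold lower number from compound 1 to compound 4 (0.13 log units; within the scatter), so the two compounds cannot be told apart in this assay. Among these compounds, this is the first direct comparison at this position. The same atoms can be joined differently here, with ethyl now on the nitrogen attached to the ring, without a step beyond the scatter.

From the compounds shown here alone, it remains open how a butyl chain or a carboxylic acid in place of the ethyl would read in this assay. Every compound shown keeps a hydroxy group on nitrogen, so its role also stays open.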